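Moving the methylsulfonyl group on a receptor agonist scaffold

This account rests on a few compounds, and the source may have more. Where it says the series, first, only, none or still open, it means among the compounds named here.

Measured so far in a functional assay on HEK293 cells for agonist activity at Glucose-dependent insulinotropic receptor (Homo sapiens), read by cAMP accumulation, with a stated time of 30 min; on this read-out higher numbers stand for an effect only at larger amounts of compound and lower numbers for an effect already at smaller amounts:
Compound 1 `CC(C)(C)OC(=O)N1CCC(n2nnc3cc(-c4ccc(S(C)(=O)=O)cc4)ccc32)CC1` gives 63 nM in this assay.
Compound 2 `CC(C)OC(=O)N1CCC(n2ncc3cc(Oc4ccc(S(C)(=O)=O)cc4)ncc32)CC1` gives 177 nM in this assay.

Of the two numbers recorded, compound 2 has the higher one, and its gap to compound 1 is beyond the usual scatter of repeated measurements. The two compounds differ in several places at once, so nothing can be said about which of those differences accounts for the gap.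

Compound 3 `CC(C)OC(=O)N1CCC(n2ncc3cc(Oc4cccc(S(C)(=O)=O)c4)ncc32)CC1` has not yet been measured. It keeps every atom of compound 2 and changes only how they are joined: 3-(methylsulfonyl)phenyl in place of 4-(methylsulfonyl)phenyl on an oxygen on an aromatic ring. Within the data shown here, no measured pair in this set shows what such a change does, so the expectation rests on the change alone. A shift of this kind is expected to leave the number roughly where it is or to raise it, as a 2.3-fold higher number from compound 2 to compound 3 (0.35 log units; beyond the scatter). Compound 3 is therefore estimated at 400 nM, with a likely range from 120 nM to 1500 nM.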

Compound 3, half-maximal effective concentration: 266 nM
For compound 3 the middle estimate is 1.5-fold (0.18 log units) above the measured one; low and high end bracket the measured number.
By their numbers in this assay, from the lowest: compound 1; then compounds 2 and 3 (each within the scatter of the next).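

In this assay, among these compounds, the first comparison in this set that differs in one place gives a 1.5-fold higher number from compound 2 to compound 3 (0.18 log units; within the scatter) and so stays within the usual scatter of repeated measurements. On this oxygen, then, 3-(methylsulfonyl)phenyl and 4-(methylsulfonyl)phenyl cannot be told apart by this read-out, which shows that for this pair the methylsulfonyl group can move around the ring with no measurable change in the number. No measurement at hand speaks to why the two arrangements read alike.

Still open, as far as these compounds go, is whether the ring needs the methylsulfonyl group at all, or whether a carboxylic acid or a primary amide in its place would read the same. Also open, from the compounds shown here alone, is whether the same move would read alike on the core of compound 1.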